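The compounds below may be only part of what the source reports. "The series", "measured", "known", "first", "only" and "open" are said of these compounds alone.

Compound 1 `Cc1cc(S(=O)(=O)/N=C(\N)n2nccc2-c2ccccc2)c(SCc2ccc(Cl)cc2)cc1Cl` gives 7000 nM in a functional assay on HCT-116 cells (Homo sapiens) for cytotoxicity, read by MTT assay, with a stated time of 72 h; on this read-out lower numbers stand for stronger inhibition and higher numbers for weaker inhibition.
Compound 2 `Cc1cc(-c2ccccc2)n(/C(N)=N/S(=O)(=O)c2cc(C)c(Cl)cc2SCc2ccccc2C(F)(F)F)n1` gives 25000 nM.
Compound 3 `Cc1cc(-c2ccccc2)n(/C(N)=N/S(=O)(=O)c2cc(C)c(Cl)cc2SCc2cccc(Cl)c2)n1` gives 18000 nM.

Compound 1 has the lowest number of the three, and its gaps to compound 3 and to compound 2 are both beyond the usual scatter, so it is the most potent measured compound here. Compound 4 `Cc1cc(S(=O)(=O)/N=C(\N)n2nccc2-c2ccccc2)c(SCc2cccc(C(F)(F)F)c2)cc1Cl` is derived from compound 1 by 3-(trifluoromethyl)phenyl in place of 4-chlorophenyl on a saturated chain carbon bound to a sulfur. Among the compounds with values here, only one measured step bears on this change: a 1.4-fold lower number from compound 2 to compound 3 (0.14 log units; within the scatter). That step also exchanges a chlorophenyl for a trifluoromethylphenyl group, on a core that differs from the core of compound 1, and it stays within the scatter. No shift beyond the scatter is therefore expected, no change at the digits printed from compound 1 to compound 4 (within the scatter). Compound 4 is estimated at 7000 nM, with a range from 3000 nM to 17000 nM.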

Compound 4, half-maximal inhibitory concentration: 14000 nM
Compound 4: the middle estimate sits 2.0-fold (0.30 log units) below what was measured; measured number inside the range.
By their numbers in this assay, from the lowest: compounds 1, 4, 3 and 2 (each within the scatter of the next, the first and the last beyond it).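

In this assay, within the data shown here, this is the first direct test of the change on the core of compound 1, and it gives a 2.0-fold higher number from compound 1 to compound 4 (0.30 log units; within the scatter). Replacing 4-chlorophenyl with the larger 3-(trifluoromethyl)phenyl on the saturated chain carbon bound to a sulfur therefore leaves the two compounds indistinguishable on this read-out. Nothing available explains this result. The compounds shown leave open whether a ring is needed at this place at all, since every group there is a substituted phenyl. An amine or a carboxylic acid there could answer that.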